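A few compounds are considered here, and "the series" means these few. Any claim that something is new, unique, unknown or untested is made for them only; others in the source may bear on it.

Measured so far in a functional assay on the whole organism with Mus musculus as the target, in the maximal electroshock model, with a stated time of 1 h; on this read-out higher numbers stand for an effect only at larger amounts of compound and lower numbers for an effect already at smaller amounts:

compound 1 `Cc1ccccc1-c1nnc(NN)s1` gives > 100 mg/kg, a limit of this assay and not a number.
compound 2 `Cc1ccccc1-c1nnc(N(N)C(C)C)s1` gives 54 mg/kg.

Compound 2 holds the only number shown in this assay; the other value is a limit. Among the measured compounds shown here, the single measured step, an at least 1.8-fold lower number from compound 1 to compound 2 (0.26 log units; that floor lies within the scatter), has a floor that lies within the scatter, so the direction it points to is weakly supported. Compound 1 sits at the limit of > 100 mg/kg in this assay, at which 1 of the 2 values shown sits. The size of that step beyond its floor is therefore unknown.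

Compound 3 `CNNc1nnc(-c2ccccc2C)s1` differs from compound 2 by (methylamino)amino in place of amino(isopropyl)amino on an aromatic carbon. For the measured compounds named here, the alkyl on that nitrogen is shortened rather than removed, so compound 3 stands between compound 1 and compound 2 in this respect, and the step from compound 1 to compound 2 is the only guide. For compound 3 a number in this assay is expected somewhat higher than that of compound 2, or within the scatter of it, as a 1.4-fold higher number from compound 2 to compound 3 (0.14 log units; within the scatter). The estimate for compound 3 is 75 mg/kg, with a range from 40 mg/kg to 150 mg/kg; a limit rather than a number remains possible.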

Compound 3, dose for half-maximal effect: > 100 mg/kg
Compound 3: only a limit was reported (the forecaster's own chance of this, stated with the estimate: 30%); middle value at least 1.3-fold (0.12 log units) from the limit.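

In this assay, the change from amino(isopropyl)amino to (methylamino)amino on this aromatic carbon gives an at least 1.8-fold higher number from compound 2 to compound 3 (0.26 log units; that floor lies within the scatter), and since that floor lies within the scatter, the direction is only weakly supported. Compound 3 gives > 100 mg/kg, which is a limit of the assay and not a number, and the step from compound 1 to compound 3 cannot be read because both values are limits. As the two group names show, this change replaces isopropyl with methyl and also moves the alkyl to the other nitrogen, so the series so far has a number only with the amino(isopropyl)amino group of compound 2, and the rest of the data offer little resolution: the limit of > 100 mg/kg in this assay, at which 2 of the 3 values shown sit.

The contributions of chain size and nitrogen placement therefore remain unseparated, and amino(methyl)amino and (isopropylamino)amino on the same carbon would each isolate one of them. On these data alone, whether a number depends on branching also stays open, with ethyl, n-propyl or cyclopropyl on the nitrogen that carries isopropyl in compound 2 as the relevant groups.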